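This account rests on a few compounds, and the source may have more. Where it says the series, first, only, none or still open, it means among the compounds named here.

In a toxicity assay on HepG2 2.2.15 cells (Homo sapiens) for cytotoxicity, read by CCK-8 assay, with a stated time of 8 days (on this read-out higher numbers stand for lower toxicity in this test and lower numbers for higher toxicity in this test), compound 2 `CC(C)Cc1nn(-c2nccs2)cc1C(=O)Nc1ccc(F)cc1` gives 83700 nM, the highest of the two numbers shown. Compound 1 `CCOC(=O)c1cn(-c2cccc(OC)c2)nc1CC(C)C` gives 70500 nM, within the scatter of that. For compound 3 `CCOC(=O)c1cn(-c2nccs2)nc1CC(C)C` the assay reports only a limit, > 100000 nM. Going by the values given here, the one measured step, an at least 1.1-fold higher number from compound 2 to compound 3 (0.07 log units; that floor lies within the scatter), changes the same carbonyl carbon that compound 4 changes, but in another way. Compound 4 `CC(C)Cc1nn(-c2nccs2)cc1C(=O)NCc1ccc(F)cc1` differs from compound 2 by 4-fluorobenzyl in place of 4-fluorophenyl on an amide-type nitrogen. Among the compounds with values here, no measured step shows this change, and the one step at that place is at most a floor within the scatter, so no step beyond the scatter is expected in this assay. Compound 4 is therefore estimated at 80000 nM, between 40000 nM and 160000 nM, a step of a 1.0-fold lower number from compound 2 to compound 4 (0.02 log units; within the scatter) expected.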

Compound 4, half-maximal cytotoxic concentration: > 100000 nM
Compound 4 was reported as a limit (the forecaster's own chance of this, stated with the estimate: 40%); at least 1.2-fold (0.09 log units) between middle value and limit.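

This step changes the group on the amide-type nitrogen rather than the ester or amide at the carbonyl carbon: in this assay, 4-fluorobenzyl in place of 4-fluorophenyl gives an at least 1.1-fold higher number from compound 2 to compound 4 (0.07 log units; that floor lies within the scatter). So this change brings no sign of higher toxicity in this test. The true size of the step cannot be read because the number for compound 4 is a limit: the limit of > 100000 nM in this assay, at which 2 of the 4 values shown sit.

Still open, on these data alone, is whether a longer chain carrying the aromatic ring on that nitrogen, or a simple amine in place of 4-fluorophenyl, would give a clearly lower number.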